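A few compounds are considered here, and "the series" means these few. Any claim that something is new, unique, unknown or untested is made for them only; others in the source may bear on it.

Compound 1 `COc1cc(C(F)(F)F)cc(SC)c1C(=O)NC1(c2ccccc2)CCCN(C)C1` is a benzamide whose core holds one stereocentre at a saturated ring carbon, drawn without a configuration, so it stands for both forms together. Among the compounds with values here, in an assay on cells for inhibition of sodium- and chloride-dependent glycine transporter 1 (Homo sapiens) (a higher number here means that more compound is needed for the effect, a lower number that less compound is needed), compound 1 gives 24 nM, the second highest of the three numbers measured so far. Compound 2 `COc1cc(C(F)(F)F)cc(SC)c1C(=O)N[C@]1(c2ccccc2)CCCN(C)C1` has that centre drawn S and gives 180 nM, while compound 3 `COc1cc(C(F)(F)F)cc(SC)c1C(=O)N[C@@]1(c2ccccc2)CCCN(C)C1` has it drawn R and gives 10 nM. The step of a 7.5-fold higher number from compound 1 to compound 2 (0.88 log units; beyond the scatter) and the step of a 2.4-fold lower number from compound 1 to compound 3 (0.38 log units; beyond the scatter) place the mixture between its two single forms, and the step of an 18-fold lower number from compound 2 to compound 3 (1.26 log units; beyond the scatter) shows how far apart those forms lie; that separation rests on (the fact that compounds 2 and 3 differ only in the configuration as drawn).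

Compound 4 `COc1cc(C(F)(F)F)cc(SC)c1C(=O)NC1(c2ccc(F)cc2)CCCN(C)C1` keeps the undefined centre of compound 1 and differs from it in one place: fluoro in place of hydrogen on an aromatic carbon, so the phenyl becomes a 4-fluorophenyl. Within the data shown here, none of the measured steps touches this ring; all three concern only the configuration at the ring carbon, so they offer no direct guide to this change. Among the measured compounds shown here, the change enters a single heavy atom, and with no measured step arguing otherwise, a step of a 1.2-fold lower number from compound 1 to compound 4 (0.08 log units; within the scatter) is expected, within the scatter. Compound 4 is therefore estimated at 20 nM, with a likely range from 7 nM to 60 nM.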

Compound 4, half-maximal effective concentration: 26 nM
Estimate against measurement, compound 4: 1.3-fold (0.11 log units) below; the range from low to high includes it.
By their numbers in this assay, from the lowest: compound 3; then compounds 1 and 4 (each within the scatter of the next); then compound 2.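

In this assay, the step of a 1.1-fold higher number from compound 1 to compound 4 (0.03 log units; within the scatter) shows that fluoro can take the place of hydrogen on this aromatic carbon, para to a large group, with no change that can be told from the usual scatter of repeated measurements. Within the data shown here, the earlier compounds differed only in the configuration at the saturated ring carbon, so this is the first reading on the phenyl ring itself: at this one position, the assay number tolerates the swap from phenyl to 4-fluorophenyl. Nothing known about these compounds bears on the reason for this result.

From the compounds shown here alone, compound 4 is drawn without a configuration, so it remains open how its two single forms would compare, given the step of an 18-fold lower number from compound 2 to compound 3 (1.26 log units; beyond the scatter) seen with the unsubstituted phenyl ring. Going by these compounds, it also remains open whether a chloro or nitrile group at this position, or fluoro elsewhere on the same ring, would leave the number just as little changed.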